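Swapping the aryl group on a cyclopentylamine ether series

The source may report more compounds than this note shows. Statements on the series, on what has been measured and on what is new or still open speak of the compounds shown alone.

Measured in a functional assay on SK-OV-3 cells (Homo sapiens) for inhibition, read by CCK-8 assay, with a stated time of 70 h; on this read-out higher numbers stand for weaker inhibition and lower numbers for stronger inhibition:

Compound 1 `Nc1ccc(COc2ccc(OCCOCCNC3CCCC3)cc2)cc1` gives 31700 nM
Compound 2 `O=[N+]([O-])c1ccc(COc2ccc(OCCOCCNC3CCCC3)cc2)cc1` gives 20300 nM

Within the data shown here, the values of compound 1 and compound 2 lie within the scatter of each other, so compound 2 stands level with the only other measured compound, and neither can be ranked above the other.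

The next compound is compound 3 `COC(=O)c1ccccc1COc1ccc(OCCOCCNC2CCCC2)cc1`, which differs from compound 2 in this way: 2-(methoxycarbonyl)phenyl in place of 4-nitrophenyl on a saturated chain carbon bound to an oxygen on an aromatic ring. A 2-(methoxycarbonyl)phenyl thus takes the place of the 4-nitrophenyl on a saturated chain carbon bound to an oxygen on an aromatic ring.

Among the measured compounds shown here, only one measured step bears on this change, and it bears only indirectly. It is a 1.6-fold lower number from compound 1 to compound 2 (0.19 log units; within the scatter), with nitro in place of amino on an aromatic carbon. For the measured compounds named here, no measured compound carries a methoxycarbonyl group, so the data offer no direct precedent, and no step beyond the scatter can be expected from them in this assay.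

The expected outcome is a 1.0-fold lower number from compound 2 to compound 3 (0.01 log units; within the scatter), with no direction favoured.

For compound 3 the estimated value is 20000 nM, with an expected range from 8000 nM to 50000 nM.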

Compound 3, half-maximal inhibitory concentration: > 100000 nM
Compound 3 was reported as a limit; the forecaster's own chance of this, stated with the estimate: 10%; middle value at least 5.0-fold (0.69 log units) away from the limit.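

In this assay compound 3 gives > 100000 nM, which is a limit of the assay and not a number. Unlike the exchange of amino for nitro, which stayed within the scatter, this change at the saturated chain carbon bound to an oxygen on an aromatic ring has a clear effect: 2-(methoxycarbonyl)phenyl in place of 4-nitrophenyl gives an at least 4.9-fold higher number from compound 2 to compound 3 (0.69 log units; beyond the scatter), and in place of 4-aminophenyl it gives an at least 3.1-fold higher number from compound 1 to compound 3 (0.49 log units; beyond the scatter). Both steps are only lower bounds, so the full size of the loss stays unknown: the limit of > 100000 nM in this assay, at which 1 of the 3 values shown sits.

The compounds shown do not separate the effect of the methoxycarbonyl group from that of where it sits on the ring, a question that a 4-(methoxycarbonyl)phenyl or a 2-nitrophenyl at this place would address. They also leave open how an unsubstituted phenyl or a 2-carboxyphenyl would read out here.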